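This account rests on a few compounds, and the source may have more. Where it says the series, first, only, none or still open, it means among the compounds named here.

Compound 1 `Oc1cccc(-c2cc(-c3cccc(F)c3)cc(-c3ccccc3O)n2)c1` — > 50000 nM
Compound 2 `Oc1ccc(-c2cc(-c3ccccc3F)cc(-c3ccccc3O)n2)cc1` — > 50000 nM

In a functional assay on HeLa cells (Homo sapiens) for inhibition (on this read-out lower numbers stand for stronger inhibition and higher numbers for weaker inhibition), compound 2 gives > 50000 nM, which is a limit of the assay and not a number. In this assay compound 1 gives > 50000 nM, again only a limit. Within the data shown here, both readings therefore sit at the limit of > 50000 nM in this assay, at which 2 of the 2 values shown sit, so compound 2 stands at the edge of what this assay can report, beside the only other measured compound, and no order between the two can be read from the numbers.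

Compound 3 `Oc1ccc(-c2cc(-c3cccc(F)c3)cc(-c3ccccc3O)n2)cc1` arises from compound 2 by a single change: 3-fluorophenyl in place of 2-fluorophenyl on an aromatic carbon. Among the measured compounds shown here, no pair of measured compounds differs in exactly this way, so no measured step supports the expectation directly. Compound 1 carries the same 3-fluorophenyl group and still returns only a limit, which gives no hint that this group alone brings the value into the measurable range. The step expected from compound 2 to compound 3 in this assay is a step that the limit leaves unreadable from compound 2 to compound 3, that is, nothing beyond the scatter. Compound 3 is accordingly expected at 80000 nM, between 20000 nM and 300000 nM, most likely reported again only as a limit.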

Compound 3, half-maximal inhibitory concentration: > 50000 nM
Compound 3: only a limit was reported; the forecaster's own chance of this, stated with the estimate: 80%; the middle value does not contradict the limit.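

In this assay compound 3 gives > 50000 nM which is again a limit and not a number. Among these compounds, no step among compound 1, compound 2 and compound 3 can be read, because all three readings stand at the same edge: the limit of > 50000 nM in this assay, at which 3 of the 3 values shown sit. The compounds shown leave open how strongly any of the three inhibits in this assay and whether moving the fluorine or the hydroxyl group changes that at all.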